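Trading Fluorines for Methoxy Groups on the Ring Nitrogen

The compounds below may be only part of what the source reports. "The series", "measured", "known", "first", "only" and "open" are said of these compounds alone.

Compound 3 `CC(F)(F)c1cccc(N2C(=O)CSC2c2cccc(C(=O)NCCCCc3ccccc3)c2)c1` gives 92% in a functional assay on MG-63 cells (Homo sapiens) for inhibition, read by CCK-8 assay, with a stated time of 72 h, tested at 1 uM; a lower number here means less inhibition, a higher number more inhibition at the concentration tested (going by the name of the read-out). That is level with compound 1 `COc1ccc(OC)c(N2C(=O)CSC2c2cccc(C(=O)NCCCCc3ccccc3)c2)c1`, which gives 92%, and together these two stand highest of the three, while compound 2 `COc1c(F)cccc1N1C(=O)CSC1c1cccc(C(=O)NCCCCc2ccccc2)c1` gives 0%. The two steps that reach compound 3 are no change at the digits printed from compound 1 to compound 3 (within the scatter) and a number 92 percentage points higher from compound 2 to compound 3 (beyond the scatter). Compound 4 `COc1ccc(N2C(=O)CSC2c2cccc(C(=O)NCCCCc3ccccc3)c2)c(OC)c1` differs from compound 3 by a group of 10 heavy atoms (8 carbon, 2 oxygen; one six-membered aromatic ring of carbon only) in place of a group of 10 heavy atoms (8 carbon, 2 fluorine; one six-membered aromatic ring of carbon only), on an amide-type nitrogen in a ring. This reverses the kind of exchange seen in no change at the digits printed from compound 1 to compound 3 (within the scatter), which bears most directly, yet a number 92 percentage points lower from compound 1 to compound 2 (beyond the scatter) shows that another change of the same aryl group removed all inhibition. Because no change at the digits printed from compound 1 to compound 3 (within the scatter) was flat, no step beyond the scatter is expected, so a number 7 percentage points lower from compound 3 to compound 4 (within the scatter). Compound 4 is therefore expected at 85%, within 40% to 97%.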

Compound 4, a percentage reported as inhibition, at one concentration (the size of the read-out at that concentration, not a potency): 56%
Compound 4: the middle estimate sits 29 percentage points above what was measured, within the range that was stated.
By their numbers in this assay, from the lowest: compound 2; then compound 4; then compounds 1 and 3 (each within the scatter of the next).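

In this assay, moving one methoxy group on the aryl ring matters: 2,4-dimethoxyphenyl in place of 2,5-dimethoxyphenyl gives a number 36 percentage points lower from compound 1 to compound 4 (beyond the scatter). The exchange between dimethoxyphenyl and the group with two fluorines, flat from compound 1, is therefore not flat for every dimethoxy pattern, with a number 36 percentage points lower from compound 3 to compound 4 (beyond the scatter). Compound 4 still keeps part of the inhibition lost with 3-fluoro-2-methoxyphenyl, showing a number 56 percentage points higher from compound 2 to compound 4 (beyond the scatter). From the compounds shown here alone, whether an aryl ring carrying a single methoxy group, an amine or a carboxylic acid would hold inhibition stays open. Nothing given here explains these differences.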